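Ring size at the alkene carbon: from cyclopropyl to cyclopentyl

The compounds below may be only part of what the source reports. "The series", "measured", "known", "first", "only" and "open" are said of these compounds alone.

Measured so far:
compound 1, `CC(C)/C(=C(/c1ccc(/C=C/C(=O)O)cc1)c1ccc2[nH]ncc2c1)c1ccccc1`, 4 nM
compound 2, `O=C(O)/C=C/c1ccc(/C(=C(\c2ccccc2)C2CC2)c2ccc3[nH]ncc3c2)cc1`, 13 nM

In a functional assay on MCF7 cells (Homo sapiens) for cytotoxicity, read by CellTiter-Glo, with a stated time of 5 days (on this read-out lower numbers stand for stronger inhibition and higher numbers for weaker inhibition), compound 2 gives 13 nM, the highest of the two numbers; its nearest neighbour is compound 1, which gives 4 nM in this assay, a difference that lies beyond the scatter. Compound 3, `O=C(O)/C=C/c1ccc(/C(=C(\c2ccccc2)C2CCCC2)c2ccc3[nH]ncc3c2)cc1`, is not yet measured. It differs from compound 2 in one place: cyclopentyl in place of cyclopropyl on a double-bonded chain carbon bound to an aromatic carbon and a double-bonded chain carbon.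

Going by the values given here, only one measured step touches this position: a 3.3-fold higher number from compound 1 to compound 2 (0.51 log units; beyond the scatter). That step shows that the group at this chain carbon matters, and that the small three-membered ring gave the weaker number of the two. Among the compounds with values here, nothing measured shows how a five-membered ring behaves here, so the direction can only be inferred loosely from the one step. Since compound 1 gave the lower number with a non-ring group of similar size to a small ring, a return toward that level seems plausible for compound 3. Compound 3 is therefore expected to give a modest step downward, a 1.6-fold lower number from compound 2 to compound 3 (0.21 log units; within the scatter), in this assay. The estimate for compound 3 is 8 nM, with a range from 3 nM to 25 nM.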

Compound 3, half-maximal inhibitory concentration: 10 nM
Estimate against measurement, compound 3: 1.3-fold (0.10 log units) below; the range from low to high includes it.
By their numbers in this assay, from the lowest: compound 1; then compounds 3 and 2 (each within the scatter of the next).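

In this assay, cyclopentyl in place of cyclopropyl gives a 1.3-fold lower number from compound 2 to compound 3 (0.11 log units; within the scatter) and so, on this double-bonded chain carbon, enlarging the carbon ring from 3 to 5 heavy atoms leaves the two compounds inseparable. Cyclopentyl in place of isopropyl gives a 2.5-fold higher number from compound 1 to compound 3 (0.40 log units; beyond the scatter) and, read together with a 3.3-fold higher number from compound 1 to compound 2 (0.51 log units; beyond the scatter) for the smaller ring, this places compound 1 apart from both ring-bearing compounds, so among these three the clear difference lies between the open isopropyl group and the two rings, not between one ring size and the other. Nothing available here accounts for that difference.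

Three compounds cannot show whether the open-chain advantage is specific to isopropyl or would also hold for a tert-butyl group or a longer chain such as n-butyl. Going by these compounds, it also remains open whether a cyclohexyl ring, or a ring carrying an oxygen atom such as tetrahydropyranyl, would stay level with the two carbon rings or move the number in either direction.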